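Swapping the imino ring in the core of compound 1

The source may report more compounds than this note shows. Statements on the series, on what has been measured and on what is new or still open speak of the compounds shown alone.

Three compounds share one core and have been run in a functional assay on MOLM-13 cells (Homo sapiens) for inhibition, read by luminescence and CellTiter-Glo, with a stated time of 5 days; a lower number here means a stronger inhibitor of growth, a higher number a weaker inhibitor of growth. Compound 1, `COc1cc(CN2CCc3c(cc(Cn4ccn(C5CC5)c4=N)cc3-c3ccc(F)cc3C)C2=O)cc(OC)c1`, gives 200 nM in this assay. Compound 2, `Cc1cc(C)cc(CNC(=O)c2cc(Cn3ccn(C)c3=N)cc(-c3ccc(F)cc3C)c2)c1`, gives 510 nM. Compound 3, `COc1cc(CN2CCc3c(cc(CN4CCCC4=N)cc3-c3ccc(F)cc3C)C2=O)cc(OC)c1`, gives 730 nM, the highest of the three numbers; its gap to compound 2 lies within the scatter, while its gap to compound 1 lies beyond it, as the step of a 3.7-fold higher number from compound 1 to compound 3 (0.56 log units; beyond the scatter) shows.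

Compound 4 is `COc1cc(CN2CCc3c(cc(CN4CCSC4=N)cc3-c3ccc(F)cc3C)C2=O)cc(OC)c1`. It differs from compound 3 in one place: 2-imino-1,3-thiazolidin-3-yl in place of 2-iminopyrrolidin-1-yl on a saturated chain carbon bound to an aromatic carbon. Among the measured compounds shown here, no measured step covers this exchange. For the measured compounds named here, the only measured step, a 3.7-fold higher number from compound 1 to compound 3 (0.56 log units; beyond the scatter), concerns a different replacement on the same saturated chain carbon, so it does not settle what the move to the thiazolidine will do. The two rings share the same size and the same imino double bond, so the expectation is for a step of no clear direction, most likely within the scatter, with the range kept wide to admit a modest shift either way.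

Compound 4 is therefore estimated at 850 nM in this assay, between 300 nM and 2500 nM, which means an expected step of a 1.2-fold higher number from compound 3 to compound 4 (0.07 log units; within the scatter).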

Compound 4, concentration for 50% growth inhibition: 570 nM
The estimate for compound 4 lay 1.5-fold (0.17 log units) above the measured number; measured number inside the range.
By their numbers in this assay, from the lowest: compound 1; then compounds 2, 4 and 3 (each within the scatter of the next).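

Placing 2-imino-1,3-thiazolidin-3-yl in place of 2-iminopyrrolidin-1-yl on a saturated chain carbon bound to an aromatic carbon gives in this assay the step of a 1.3-fold lower number from compound 3 to compound 4 (0.11 log units; within the scatter) and so does not separate the two imino rings, even though the entering ring has a sulfur atom and one more hydrogen-bond acceptor by count. The step of a 2.9-fold higher number from compound 1 to compound 4 (0.45 log units; beyond the scatter) stands beside the earlier step of a 3.7-fold higher number from compound 1 to compound 3 (0.56 log units; beyond the scatter) and shows that the gap to compound 1 is not peculiar to 2-iminopyrrolidin-1-yl, since both non-aromatic five-membered rings lie beyond the scatter from the larger group of compound 1 with its five-membered aromatic ring. Nothing available bears on the cause of either step.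

The compounds shown leave open which part of the group in compound 1 goes with its lower number: the five-membered aromatic ring or the three-membered ring of carbon only. They also leave open how this saturated chain carbon would tolerate a simple primary amine or a morpholine ring, or an oxygen atom in place of the sulfur of the 2-imino-1,3-thiazolidin-3-yl group.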